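Dropping a Methyl From the Core of Compound 2

The source may hold more compounds than are shown below. What is called first, only, known or untested is meant among the compounds shown, and "the series" means these compounds.

Of the compounds shown here, three have been measured in an assay for inhibition of Amine oxidase [flavin-containing] B (Homo sapiens), read by fluorescence, using microsomes, with a stated time of 30 min; on this read-out lower numbers stand for stronger inhibition and higher numbers for weaker inhibition. Compound 1 `CN(C)Cc1cc(=O)oc2cc(OCc3ccc(CO)cc3)ccc12` gives 630 nM. Compound 2 `Cc1c(C)c2ccc(OCC3CCN(Cc4ccc(CO)cc4)CC3)cc2oc1=O` gives 29 nM, the lowest number of the three; its nearest neighbour is compound 3 `Cc1c(C)c2ccc(OCC3CCN(Cc4cccc(CO)c4)CC3)cc2oc1=O`, which gives 76 nM, and compound 1 stands furthest from it. Within the data shown here, the one single-point step among the measured compounds, a 2.6-fold higher number from compound 2 to compound 3 (0.42 log units; beyond the scatter), concerns the hydroxymethyl on the benzyl group, not the core.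

Compound 4 `Cc1cc(=O)oc2cc(OCC3CCN(Cc4ccc(CO)cc4)CC3)ccc12` has not yet been measured in this assay. Its difference from compound 2 is hydrogen in place of methyl on an aromatic carbon. Among the measured compounds shown here, no measured step touches this carbon: compound 1 differs from compound 2 in several places at once, so the gap between them cannot be assigned to the methyl alone. The change is the loss of one carbon and nothing else, so the expectation is a step in this assay that is small, possibly a slight weakening, and not reliably beyond the scatter. The estimated step is a 1.6-fold higher number from compound 2 to compound 4 (0.19 log units; within the scatter). Compound 4 is therefore estimated at 45 nM, with a range from 15 nM to 140 nM.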

Compound 4, half-maximal inhibitory concentration: 600 nM
Compound 4: the middle estimate sits 13-fold (1.12 log units) below what was measured, outside the stated range (above it).
By their numbers in this assay, from the lowest: compound 2; then compound 3; then compounds 4 and 1 (each within the scatter of the next).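

In this assay hydrogen in place of methyl gives a 21-fold higher number from compound 2 to compound 4 (1.32 log units; beyond the scatter) even though the change removes a single carbon and alters no ring, hydrogen-bond donor, hydrogen-bond acceptor or net charge. Among these compounds, this is the first measured step at this aromatic carbon, two atoms from the ring oxygen and ortho to the other methyl group, and it shows that this methyl is far from a silent part of the core of compound 2: for this pair, much of the low number depends on it. No supporting information bears on why so small a change produces so large a step.

The compounds shown leave open whether an ethyl group, a chlorine atom or a methoxy group on this carbon would hold the number of compound 2, or whether only methyl does. They also leave open whether the other methyl group counts for as much, and whether losing this methyl costs the same when 3-(hydroxymethyl)phenyl replaces 4-(hydroxymethyl)phenyl, as it does in compound 3.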